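Methyl Added to the Phenyl Ring of Compound 3

This account rests on a few compounds, and the source may have more. Where it says the series, first, only, none or still open, it means among the compounds named here.

Compound 1 `COc1ccc(-c2cccc(C(=O)Nc3nn[nH]n3)n2)cc1` and compound 2 `COc1ccc(-c2cc(C)cc(C(=O)Nc3nn[nH]n3)n2)cc1` share a core and differ at a single aromatic carbon. In a functional assay on the whole organism with Rattus norvegicus as the target, at a dose of 3 mg/kg by the oral route (a higher number here means a stronger effect of the compound at the dose given, a lower number a weaker effect), compound 1 gives 36%, and compound 2 gives 43%. The step of a number 7 percentage points higher from compound 1 to compound 2 (within the scatter) arises from methyl in place of hydrogen on an aromatic carbon. Compound 3 `CCCCc1cc(C(=O)Nc2nn[nH]n2)nc(-c2ccccc2)c1` carries a butyl chain and a phenyl group; the difference between its core and that of compound 1 is not broken down here. In this assay compound 3 gives 71%, the highest of the three numbers, standing beyond the scatter from both compound 2 and compound 1. Compound 4 `CCCCc1cc(C(=O)Nc2nn[nH]n2)nc(-c2cccc(C)c2)c1` has not been measured; it differs from compound 3 by methyl in place of hydrogen on an aromatic carbon. This is the same kind of change as that from compound 1 to compound 2, but its surroundings differ: there the methyl entered a six-membered aromatic ring with 1 nitrogen, meta to two groups of 8 heavy atoms each and opposite the ring nitrogen, whereas here it enters a six-membered aromatic ring of carbon only, meta to a large group. Because a number 7 percentage points higher from compound 1 to compound 2 (within the scatter) stayed within the scatter, a similarly small step is expected, a number 3 percentage points higher from compound 3 to compound 4 (within the scatter). Compound 4 is accordingly estimated at 74% in this assay, most likely between 58% and 88%.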

Compound 4, a percentage reported as inhibition, in the whole organism at one dose (the size of the read-out at that dose, not a potency): 82%
Compound 4: the middle estimate sits 8 percentage points below what was measured; the measured number falls inside the stated range.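

In this assay, methyl in place of hydrogen on an aromatic carbon, here phenyl to 3-methylphenyl, gives a number 11 percentage points higher from compound 3 to compound 4 (beyond the scatter), a modest step. Set beside the earlier step, the change carries from one core to the other in the same direction, and the two sizes cannot be told apart: the same change on two cores in this assay, a number 7 percentage points higher (within the scatter) from compound 1 to compound 2 and a number 11 percentage points higher (beyond the scatter) from compound 3 to compound 4, 4 percentage points apart, within the scatter of two such steps This does not show that the step has a fixed size across the series, since it rests on only two pairs, with the methyl on a different ring in each, and the data do not explain why only the second step lies beyond the scatter.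

The compounds shown leave open whether a group other than methyl, such as ethyl, chlorine or trifluoromethyl, would give a similar step at the same place on the phenyl ring. They also leave open how a chain longer than butyl would read in this assay on the core of compound 4.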